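This account rests on a few compounds, and the source may have more. Where it says the series, first, only, none or still open, it means among the compounds named here.

Measured so far:
- compound 1 `O=c1c(Cl)c(CSC(=S)N2CCOCC2)oc2ccccc12`: 4100 nM
- compound 2 `COc1ccc2occ(CSC(=S)N3CCCC3)c(=O)c2c1`: 1800 nM
- compound 3 `O=c1cc(CSC(=S)N2CCCC2)oc2cc(Cl)ccc12`: > 25000 nM

In a functional assay on MDA-MB-435S cells (Homo sapiens) for antiproliferative activity, read by MTT assay, with a stated time of 72 h (on this read-out higher numbers stand for weaker inhibition and lower numbers for stronger inhibition), compound 1 stands at the highest of the two numbers obtained, so it inhibits more weakly than compound 2, and the gap between them lies beyond the usual scatter. For compound 3 the assay reports only a limit, not a number (the limit of > 25000 nM in this assay, at which 1 of the 3 values shown sits); nothing further is drawn from it.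

Compound 4 `CC(C)N(C(=S)SCc1oc2ccccc2c(=O)c1Cl)C(C)C` is the next variant of compound 1. The change is diisopropylamino in place of morpholin-4-yl on a thiocarbonyl carbon. Going by the values given here, no measured pair shows this kind of exchange, so there is no step to lean on. The expectation is that the step from compound 1 to compound 4 stays small, possibly a slight gain in potency but more likely nothing beyond the scatter: a 1.4-fold lower number from compound 1 to compound 4 (0.14 log units; within the scatter). Compound 4 is therefore estimated at 3000 nM in this assay, within a range from 1000 nM to 10000 nM.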

Compound 4, half-maximal inhibitory concentration: 23600 nM
The estimate for compound 4 lay 7.9-fold (0.90 log units) below the measured number; the whole stated range lies below it.
By their numbers in this assay, from the lowest: compound 2; then compound 1; then compound 4. At a limit, above all of these: compound 3.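

On the core of compound 1, the group on the thiocarbonyl carbon proves to be more than a neutral exchange: in this assay, the change gives a 5.8-fold higher number from compound 1 to compound 4 (0.76 log units; beyond the scatter). Going by these compounds alone, this is the first single-place step, and it favours morpholin-4-yl, with its six-membered ring, over the open diisopropylamino group. Little numeric room remains above compound 4, and compound 3 is reported only as a limit: the limit of > 25000 nM in this assay, at which 1 of the 4 values shown sits.

One step cannot separate the loss of the ring from the loss of the ring oxygen, nor show whether the same step holds on the cores of compound 2 and compound 3. Piperidin-1-yl and dimethylamino on the core of compound 1 would bear on both the ring and the size of the amine.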